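The compounds below may be only part of what the source reports. "The series", "measured", "known", "first", "only" and "open" are said of these compounds alone.

Measured so far in an assay for inhibition of protein disulfide-isomerase (Homo sapiens), with a stated time of 1 h; on this read-out higher numbers stand for weaker inhibition and lower numbers for stronger inhibition:
- compound 1 `Cc1ccnc(NC(c2ccccc2F)c2ccc3cccnc3c2O)c1`: 880 nM
- compound 2 `Cc1ccnc(NC(c2ccc(F)cc2)c2ccc3cccnc3c2O)c1`: 140 nM
- compound 3 `Cc1ccnc(NC(c2ccc3cccnc3c2O)c2c(F)cccc2Cl)c1`: > 40000 nM

Going by the values given here, compound 3 is the one compound whose result is a limit of this assay, not a number (the limit of > 40000 nM in this assay, at which 1 of the 3 values shown sits). Among the numbers shown it therefore stands at the weak end, with compound 1 and compound 2 both giving real values.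

Compound 4 `Cc1ccnc(NC(c2ccccc2C)c2ccc3cccnc3c2O)c1` is not yet measured. Its change from compound 3 is 2-methylphenyl in place of 2-chloro-6-fluorophenyl on a saturated chain carbon bound to an aromatic carbon and a nitrogen on an aromatic ring. Among the compounds with values here, three measured steps bear on it. The closest is an at least 45-fold higher number from compound 1 to compound 3 (1.65 log units; beyond the scatter), the reverse of which amounts to stripping the chloro from the ring; compound 4 likewise carries no chloro and, like compound 1, has a single group on that phenyl ring, a methyl where compound 1 has a fluoro. The step of an at least 280-fold higher number from compound 2 to compound 3 (2.45 log units; beyond the scatter) shows the same direction on a larger scale, and a 6.3-fold lower number from compound 1 to compound 2 (0.80 log units; beyond the scatter) shows that the pattern on this phenyl ring matters within the series.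

The expectation for compound 4 is therefore a large step down from the limit, an at least 13-fold lower number from compound 3 to compound 4 (1.12 log units; beyond the scatter), landing near compound 1 or somewhat weaker, since a methyl is not a fluoro. Compound 4 is estimated at 3000 nM, within 700 nM to 20000 nM.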

Compound 4, half-maximal inhibitory concentration: > 40000 nM
Compound 4: no number, only a limit; the forecaster's own chance of this, stated with the estimate: 15%; at least 13-fold (1.12 log units) between middle value and limit.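

In this assay, replacing one group on the phenyl ring is enough to lose any readable value: an at least 45-fold higher number from compound 1 to compound 4 (1.65 log units; beyond the scatter), with methyl in place of fluoro on an aromatic carbon. The loss at compound 3 therefore has a counterpart without a chloro or a second group on this ring, so it cannot be tied to the 2-chloro-6-fluorophenyl pattern alone. Going by these compounds alone, the step of an at least 280-fold higher number from compound 2 to compound 4 (2.45 log units; beyond the scatter) sets 2-methylphenyl against 4-fluorophenyl on the same saturated chain carbon and is large, which leaves compound 1 and compound 2 as the only members with real numbers. Compound 3 and compound 4 both end at a limit of the assay, not a number, so the step between them cannot be read: the limit of > 40000 nM in this assay, at which 2 of the 4 values shown sit.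

Going by these compounds, whether the loss belongs to methyl as such or to any group other than fluoro on this ring stays open, and a lone chloro, a methoxy or an amine on the phenyl ring would test that. The plain phenyl, with no group on the ring at all, also stands outside the compounds shown, so the effect of the fluoro itself has no baseline.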